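Anilino and methoxy replace benzylsulfanyl and hydroxyl on the chain

A few compounds are considered here, and "the series" means these few. Any claim that something is new, unique, unknown or untested is made for them only; others in the source may bear on it.

Compound 2 `OC(CSCc1ccccc1)CN1CCN(CCCC(c2ccc(F)cc2)c2ccc(F)cc2)CC1` carries a 2-(benzylsulfanyl)-1-hydroxyethyl group on the saturated chain carbon bound to the amine nitrogen in a ring. In a functional assay (brain) with Canis familiaris (Canis lupus familiaris) as the target (a higher number here means a weaker inhibitor, a lower number a stronger inhibitor), compound 2 gives 28000 nM, the highest of the three numbers measured. Compound 1 `CC(=O)OC(CNc1ccccc1)CN1CCN(CCCC(c2ccc(F)cc2)c2ccc(F)cc2)CC1` gives 13000 nM in this assay, and compound 3 `OC(CNCc1ccccc1)CN1CCN(CCCC(c2ccc(F)cc2)c2ccc(F)cc2)CC1` gives 6900 nM; both gaps from compound 2 lie beyond the scatter. Compound 4 `COC(CNc1ccccc1)CN1CCN(CCCC(c2ccc(F)cc2)c2ccc(F)cc2)CC1` is not yet measured; it differs from compound 2 by 2-anilino-1-methoxyethyl in place of 2-(benzylsulfanyl)-1-hydroxyethyl on a saturated chain carbon bound to an amine nitrogen in a ring. Among the measured compounds shown here, one measured step bears on part of this change: a 4.1-fold lower number from compound 2 to compound 3 (0.61 log units; beyond the scatter). For the measured compounds named here, no measured pair isolates a methoxy group in place of the hydroxyl, but compound 1, which pairs the anilino group with an acetoxy group, gives 13000 nM, a number sitting between those of compound 2 and compound 3. The expected step is therefore a 3.1-fold lower number from compound 2 to compound 4 (0.49 log units; beyond the scatter), a modest lowering of the number. The estimate for compound 4 in this assay is 9000 nM, within a range from 3000 nM to 27000 nM.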

Compound 4, half-maximal inhibitory concentration: 15000 nM
Compound 4: middle estimate off by 1.7-fold (0.22 log units), on the low side, and the stated range covers the measured number.
By their numbers in this assay, from the lowest: compounds 3, 1, 4 and 2 (each within the scatter of the next, the first and the last beyond it).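

In this assay, the full exchange of groups gives a 1.9-fold lower number from compound 2 to compound 4 (0.27 log units; within the scatter) and so stays within the scatter, whereas the benzylamino change alone had moved the number beyond it. Methyl in place of acetyl on the oxygen gives a 1.2-fold higher number from compound 1 to compound 4 (0.06 log units; within the scatter) and is the first measured change confined to that oxygen, which leaves the two compounds indistinguishable in this read-out. The step of a 2.2-fold higher number from compound 3 to compound 4 (0.34 log units; beyond the scatter) lies beyond the scatter, so 2-(benzylamino)-1-hydroxyethyl still carries the lowest number among these groups at this place. The compounds shown leave open how the anilino group behaves with a free hydroxyl, and whether an ethoxy group on that oxygen would match the methoxy group. Nothing shown accounts for any of these numbers.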